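Hydroxylamine N-substituent change in a naphthyl enone series

The source may report more compounds than this note shows. Statements on the series, on what has been measured and on what is new or still open speak of the compounds shown alone.

Measured compounds:
- Compound 1 `CN(O)/C=C\C(=O)c1ccc2ccccc2c1`: 1800 nM
- Compound 2 `O=C(/C=C\N(O)c1ccccc1)c1ccc2ccccc2c1`: 810 nM

Both compounds share a core in which a hydroxylamine nitrogen is joined through a double-bonded chain carbon to a carbonyl on a naphthalene ring. They were tested in an assay on RBL-1 cells for inhibition of Polyunsaturated fatty acid 5-lipoxygenase (Rattus norvegicus); a lower number here means a stronger inhibitor, a higher number a weaker inhibitor. Compound 1 gives 1800 nM, and compound 2 gives 810 nM. Of the two numbers, compound 2 stands lowest, so it is the stronger inhibitor of the pair. Within the data shown here, the single measured step, a 2.2-fold lower number from compound 1 to compound 2 (0.35 log units; beyond the scatter), involved phenyl in place of methyl on the amine nitrogen.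

Compound 3 `O=C(/C=C\N(O)Cc1ccccc1)c1ccc2ccccc2c1` has not yet been measured. It differs from compound 2 as follows: benzyl in place of phenyl on an amine nitrogen. Among the measured compounds shown here, no measured step covers this particular exchange; the only step at hand shows that moving from a small alkyl to an aromatic group on this nitrogen brought a modest gain. A benzyl group is neither of those, so no confident direction can be drawn from it. The expectation for compound 3 is therefore a number close to that of compound 2, with the change a 1.1-fold higher number from compound 2 to compound 3 (0.05 log units; within the scatter) likely within the scatter. The estimate for compound 3 in this assay is 900 nM, in a range from 400 nM to 2000 nM.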

Compound 3, half-maximal inhibitory concentration: 1600 nM
Compound 3: middle estimate off by 1.8-fold (0.25 log units), on the low side; the measured number falls inside the stated range.
By their numbers in this assay, from the lowest: compounds 2, 3 and 1 (each within the scatter of the next, the first and the last beyond it).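

In this assay the benzyl group on this amine nitrogen cannot be told apart from either of the other two groups: the exchange for phenyl gives a 2.0-fold higher number from compound 2 to compound 3 (0.30 log units; within the scatter) and the comparison with the methyl compound gives a 1.1-fold lower number from compound 1 to compound 3 (0.05 log units; within the scatter) and both steps stay within the usual scatter of repeated measurements. Among these compounds, compound 1 and compound 2 are still the only pair separated beyond that scatter, so the modest gain seen with phenyl cannot be said to carry over to benzyl, even though both groups hold the same kind of aromatic ring. No measurement is available that would explain these numbers.

On these data alone, with only methyl, phenyl and benzyl on this nitrogen, it remains open whether a longer chain ending in a phenyl ring, such as 2-phenylethyl, would fall closer to compound 2 or to compound 1. As far as these compounds go, it is also open whether a chlorine or a methoxy group on the phenyl ring of compound 2 would move the number beyond the scatter in either direction.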